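Lengthening the Linker Between the Aryl Ether and Phenyl

The compounds below may be only part of what the source reports. "The series", "measured", "known", "first", "only" and "open" are said of these compounds alone.

Measured compounds in an ADME assay on Huh-7 cells (Homo sapiens) for cytotoxicity, read by MTT assay, with a stated time of 3 days; on this read-out lower numbers stand for higher toxicity in this test and higher numbers for lower toxicity in this test:
compound 1 `O=C(/C=C/c1ccccc1Oc1ccccc1)NO`: 66000 nM
compound 2 `O=C(/C=C/c1ccc(OCc2ccccc2)cc1)NO`: 9900 nM
compound 3 `O=C(/C=C/c1ccc(Oc2ccccc2)cc1)NO`: 20000 nM

All three share a hydroxamic acid on an unsaturated chain attached to an aromatic ring, and differ only in the ether-linked side group and where it sits. Compound 2 has the lowest number of the three in this assay, and both of its gaps to the others are beyond the usual scatter, so it is the most toxic of these three in this test. Compound 3 stands nearest to it, compound 1 furthest away.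

Compound 4 `O=C(/C=C/c1ccc(OCCc2ccccc2)cc1)NO` has not yet been measured. It differs from compound 2 in one place:
benzyl in place of phenyl on a saturated chain carbon bound to an oxygen on an aromatic ring

For the measured compounds named here, no pair of measured compounds shows this kind of change, so the size of its effect cannot be read from the numbers above. Since the ring and its attachments stay the same and only the chain grows by one carbon, compound 4 is expected to stay close to compound 2, with a step of a 1.1-fold lower number from compound 2 to compound 4 (0.04 log units; within the scatter) that would be within or just at the edge of the scatter. Compound 4 is therefore estimated at 9000 nM, in a range from 4000 nM to 25000 nM.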

Compound 4, half-maximal cytotoxic concentration: 16000 nM
For compound 4 the middle estimate is 1.8-fold (0.25 log units) below the measured one; the range from low to high includes it.
By their numbers in this assay, from the lowest: compounds 2, 4 and 3 (each within the scatter of the next, the first and the last beyond it); then compound 1.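

In this assay, benzyl in place of phenyl on a saturated chain carbon bound to an oxygen on an aromatic ring gives a 1.6-fold higher number from compound 2 to compound 4 (0.21 log units; within the scatter), so this swap leaves the two compounds indistinguishable in this test. For the compounds shown here, this is the first pair here that differs in only one place, and it shows that the read-out at this position tolerates this change without a clear shift, though one pair cannot establish a trend. Nothing measured here explains this result.

Going by these compounds, it remains open whether a longer chain, such as phenylpropyl in place of benzyl, would also stay close to compound 2, or whether an amine or a carboxylic acid on that chain would move the number. It is also unknown whether the same swap would behave alike with the side group placed as in compound 1.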